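The source may report more compounds than this note shows. Statements on the series, on what has been measured and on what is new or still open speak of the compounds shown alone.

Measured so far:
Compound 1, `O=S(=O)(/C=C/c1ccc(Cl)cc1Cl)Cc1ccc(Nc2ncnc3ccccc23)cc1`, gives 4000 nM in a functional assay on MCF7 cells (Homo sapiens); a lower number here means a stronger inhibitor of growth, a higher number a weaker inhibitor of growth.
Compound 2, `O=S(=O)(/C=C/c1ccc(Cl)cc1)Cc1ccc(Nc2ncnc3ccc(Br)cc23)cc1`, gives 46000 nM in this assay.
Compound 3, `O=S(=O)(/C=C/c1ccc(Cl)cc1Cl)Cc1ccc(Nc2ncnc3ccc(Br)cc23)cc1`, gives 4000 nM in this assay.

Compounds 1 and 3 share one core and differ in a single spot: no change at the digits printed from compound 1 to compound 3 (within the scatter). Compounds 2 and 3 differ in a single spot as well, and here the step is large: a 12-fold lower number from compound 2 to compound 3 (1.06 log units; beyond the scatter). The change is chloro in place of hydrogen on an aromatic carbon. The cores of compound 1 and compound 2 differ in more than one place, so the difference between the two cores is not broken down here.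

The compound still to be measured is compound 4, `O=S(=O)(/C=C/c1ccc(Cl)cc1Cl)Cc1ccc(Nc2ncnc3cc(Cl)ccc23)cc1`. It is built from compound 1 by chloro in place of hydrogen on an aromatic carbon. For the measured compounds named here, this is the same kind of change as the one from compound 2 to compound 3, not the same change: there the entering chloro sat ortho to a large group and meta to a chloro group, whereas in compound 4 it sits on a ring that is part of a fused or bridged system of two rings, meta to a fused ring and para to a fused ring. The closest guide among the measured compounds is the step from compound 1 to compound 3, where a bromo entering the same fused system left the number unchanged within the scatter. Going by the values given here, on that basis compound 4 is expected to show no change at the digits printed from compound 1 to compound 4 (within the scatter), a much smaller step than the one seen from compound 2 to compound 3. The estimate for compound 4 is therefore 4000 nM, with a likely range from 1500 nM to 12000 nM.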

Compound 4, concentration for 50% growth inhibition: 25000 nM
Estimate against measurement, compound 4: 6.3-fold (0.80 log units) below; the whole stated range lies below it.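

In this assay, putting chloro in place of hydrogen on an aromatic carbon of the fused system of two rings gives a 6.3-fold higher number from compound 1 to compound 4 (0.80 log units; beyond the scatter), so in this pair the added chloro goes with weaker growth inhibition. A change of the same kind therefore cannot be carried from one core to another in this series and be expected to act in the same way, since it moved the number in opposite directions on the two cores: the same change on two cores in this assay, a 12-fold lower number (1.06 log units; beyond the scatter) from compound 2 to compound 3 and a 6.3-fold higher number (0.80 log units; beyond the scatter) from compound 1 to compound 4, 72-fold (1.86 log units) apart, beyond the scatter of two such steps What this does not show is why the two steps part: the two chloro groups enter at different places and on different cores, and with a single pair for each step, the effect of the place cannot be separated from that of the core.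

On these data alone, it remains open whether the weaker inhibition in compound 4 belongs to chloro itself or would come with other groups on the same carbon, such as a methyl, a methoxy or an amine. As far as these compounds go, it is also open whether a chloro at this place would give a step of the same direction and size on the core of compound 2.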